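The source may report more compounds than this note shows. Statements on the series, on what has been measured and on what is new or still open speak of the compounds shown alone.

Working notes on the series.

Compound 1 `O=C(N/N=C/C1CCCCC1)c1ccc(O[C@@H]2O[C@H](CO)[C@@H](O)[C@H](O)[C@H]2O)cc1` and compound 2 `O=C(N/N=C/c1cccc(Cl)c1)c1ccc(O[C@@H]2O[C@H](CO)[C@@H](O)[C@H](O)[C@H]2O)cc1` share one core and differ only at the carbon with a double bond to nitrogen. In a functional assay on MDA-MB-231 cells (Homo sapiens) for inhibition, read by MTT assay, with a stated time of 24 h, tested at 100 uM (on this read-out lower numbers stand for less inhibition and higher numbers for more inhibition at the one concentration tested (going by the name of the read-out)), compound 1 gives 0.88%. In this assay compound 2 gives 5.02%. Among the compounds with values here, the single measured step, a number 4.1 percentage points higher from compound 1 to compound 2 (within the scatter), is within the scatter, so the two numbers cannot be ordered. Compound 2 holds the higher of the two numbers, but the gap to compound 1 is within the scatter, so no ranking follows.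

Compound 3 `Cc1ccc(/C=N/NC(=O)c2ccc(O[C@@H]3O[C@H](CO)[C@@H](O)[C@H](O)[C@H]3O)cc2)cc1` is the next member. Its change from compound 2 is 4-methylphenyl in place of 3-chlorophenyl on a carbon with a double bond to nitrogen. Within the data shown here, only the step from compound 1 to compound 2 touches this position, and it stayed within the scatter even though cyclohexyl gave way to 3-chlorophenyl; nothing measured separates one aromatic group at this place from another. No step beyond the scatter is therefore expected in this assay on going from compound 2 to compound 3.

Compound 3 is estimated at 4% in this assay, with a range from 0% to 12%. The expected step from compound 2 is a number 1 percentage points lower from compound 2 to compound 3 (within the scatter), within the scatter.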

Compound 3, a percentage reported as inhibition, at one concentration (the size of the read-out at that concentration, not a potency): 9.28%
Compound 3: middle estimate off by 5.3 percentage points, on the low side; measured number inside the range.
By their numbers in this assay, from the lowest: compounds 1, 2 and 3 (each within the scatter of the next).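

The exchange of 3-chlorophenyl for 4-methylphenyl on the carbon with a double bond to nitrogen gives a number 4.3 percentage points higher from compound 2 to compound 3 (within the scatter) in this assay, so a second aromatic pair at this place now stands unseparated, one differing in a chlorine as against a methyl group and in where the substituent is named on the ring. The replacement of cyclohexyl by 4-methylphenyl gives a number 8.4 percentage points higher from compound 1 to compound 3 (within the scatter) and is the largest step printed so far, yet even this comparison of the two ends of the set does not leave the scatter, which means that the three groups tried at this position cannot be put in any order. No measurement is at hand that would bear on any reason behind these numbers.

From the compounds shown here alone, what remains open is whether a group of another kind on the carbon with a double bond to nitrogen, such as an amine, a carboxylic acid or a longer alkyl chain, would produce a step beyond the scatter in this assay at all. Equally open, going by these compounds, is whether a change elsewhere on the shared core would do so, given that all three compounds keep that core unchanged.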